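The compounds below may be only part of what the source reports. "The series", "measured", "known", "first", "only" and "open" are said of these compounds alone.

In a functional assay on Jurkat cells (Homo sapiens) for antiproliferative activity, read by MTT assay, with a stated time of 72 h (a lower number here means a stronger inhibitor, a higher number a weaker inhibitor), compound 1 `CCOc1ccc(-c2ncnn2-c2cc(OC)c(OC)c(OC)c2)cc1` gives 5 nM. Compound 2 `COc1cc(-n2ncnc2-c2cccc(Cl)c2)cc(OC)c1OC` gives only a limit, > 10000 nM, and not a number. Its place on the numbers shown is the limit of > 10000 nM in this assay, at which 1 of the 2 values shown sits.

Compound 3 `COc1cc(-n2ncnc2-c2ccc(SC)cc2)cc(OC)c1OC` is reached from compound 2 by one change: 4-(methylsulfanyl)phenyl in place of 3-chlorophenyl on an aromatic carbon. In words, 4-(methylsulfanyl)phenyl stands in place of 3-chlorophenyl on an aromatic carbon, and the rest of the structure stays the same.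

Going by the values given here, no measured step isolates such a change, so the expectation rests on a single comparison. Sharing its core with compound 2, compound 1 gives 5 nM while carrying a different aryl group, one that resembles the entering group more closely than the leaving one. A large gain in this assay is therefore expected, an estimated at least 250-fold lower number from compound 2 to compound 3 (2.39 log units; beyond the scatter). For compound 3 the estimated value is 40 nM, with an expected range of 4 nM to 800 nM.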

Compound 3, half-maximal inhibitory concentration: 50 nM
Compound 3: middle estimate off by 1.3-fold (0.10 log units), on the low side, and the stated range covers the measured number.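

In this assay, the change from 3-chlorophenyl to 4-(methylsulfanyl)phenyl on this aromatic carbon gives an at least 200-fold lower number from compound 2 to compound 3 (2.30 log units; beyond the scatter), so with the rest of the structure held constant, the aryl group at this position strongly affects the read-out. Compound 2 gives a limit and not a number: the limit of > 10000 nM in this assay, at which 1 of the 3 values shown sits. Methylsulfanyl in place of ethoxy on an aromatic carbon gives a 10-fold higher number from compound 1 to compound 3 (1.00 log units; beyond the scatter), showing that this substituent also moves the number beyond the scatter, although compound 3 remains in the nanomolar range.

The compounds shown do not separate the effect of the chlorine from that of its place on the phenyl ring. They also do not separate the sulfur from the chain length in the step from ethoxy to methylsulfanyl, a question that an ethylsulfanyl group would address directly.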